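The source may report more compounds than this note shows. Statements on the series, on what has been measured and on what is new or still open speak of the compounds shown alone.

Of the compounds shown here, two have been measured so far. Compound 1 `Oc1ccc(-c2cc(-c3cccs3)cc(-c3ccc(O)cc3)n2)cc1` reaches only a limit in a functional assay on HeLa cells (Homo sapiens) for cytotoxicity, read by CCK-8 assay (on this read-out higher numbers stand for weaker inhibition and lower numbers for stronger inhibition), giving > 50000 nM. Going by the values given here, compound 2 `Oc1ccc(-c2cc(-c3ccsc3)cc(-c3cccc(O)c3)n2)cc1` is the one compound with an actual number in this assay, where compound 2 gives 2580 nM. The other value shown, that of compound 1, is a limit (the limit of > 50000 nM in this assay, at which 1 of the 2 values shown sits). Compound 3 `Oc1ccc(-c2cc(-c3ccsc3)cc(-c3ccc(O)cc3)n2)cc1` has not yet been measured; it differs from compound 2 in 4-hydroxyphenyl in place of 3-hydroxyphenyl on an aromatic carbon. Among the compounds with values here, no step between measured compounds is available to set the size of this change, so the expectation rests on the structures alone: in this assay a weakening beyond the usual scatter is expected, the step being estimated at a 5.8-fold higher number from compound 2 to compound 3 (0.76 log units; beyond the scatter). Compound 3 is accordingly expected to give 15000 nM, with a range from 4000 nM to 50000 nM.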

Compound 3, half-maximal inhibitory concentration: 4370 nM
Compound 3: the middle estimate sits 3.4-fold (0.54 log units) above what was measured; the range from low to high includes it.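

With thiophen-3-yl in place, 4-hydroxyphenyl in place of 3-hydroxyphenyl next to the ring nitrogen gives no change that stands out from the scatter in this assay: a 1.7-fold higher number from compound 2 to compound 3 (0.23 log units; within the scatter). The thiophene attachment carries the larger step, with thiophen-3-yl in place of thiophen-2-yl giving an at least 11-fold lower number from compound 1 to compound 3 (1.05 log units; beyond the scatter). That step rests on a limit, the one reached by compound 1: the limit of > 50000 nM in this assay, at which 1 of the 3 values shown sits.

Going by these compounds, what stays open is whether 3-hydroxyphenyl and 4-hydroxyphenyl would also match in a compound carrying thiophen-2-yl. On these data alone, it is also open how a 4-aminophenyl or 4-methoxyphenyl group would fare on this same carbon.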